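Adding Chloro: What to Expect for an Unmeasured Compound

The source may hold more compounds than are shown below. What is called first, only, known or untested is meant among the compounds shown, and "the series" means these compounds.

Compound 1 `CC1=C(C(=O)Nc2ccc([N+](=O)[O-])cc2)C(c2ccc(Br)cc2)N=C(SCc2ccccc2)N1` gives 2.1% in a functional assay on the whole organism (artery, strain albino) with Rattus norvegicus as the target, with a stated time of 15 min, at a dose of 10 mg/kg by the oral route; on this read-out higher numbers stand for more inhibition at the one dose given (going by the name of the read-out) and lower numbers for less inhibition. Compound 2 `CC1=C(C(=O)Nc2ccc([N+](=O)[O-])cc2)C(c2ccc(Br)cc2)N=C(SCc2ccccc2Cl)N1` differs from it by chloro in place of hydrogen on an aromatic carbon; the step is a number 0.6 percentage points lower from compound 1 to compound 2 (within the scatter), and in this assay compound 2 gives 1.5%. Compound 3 `CC1=C(C(=O)Nc2ccc([N+](=O)[O-])cc2)C(c2cccc([N+](=O)[O-])c2)N=C(SCc2ccccc2)N1` differs from compound 1 by 3-nitrophenyl in place of 4-bromophenyl on a saturated ring carbon; here the step is a number 0.5 percentage points higher from compound 1 to compound 3 (within the scatter), and compound 3 gives 2.6%. All three numbers lie within the usual scatter of one another, so no order among them can be read. Compound 4 `CC1=C(C(=O)Nc2ccc([N+](=O)[O-])cc2)C(c2cccc([N+](=O)[O-])c2)N=C(SCc2ccccc2Cl)N1` has not been measured; it differs from compound 3 by chloro in place of hydrogen on an aromatic carbon, which is the same change, in the same place, as that between compound 1 and compound 2. Because that earlier step was a number 0.6 percentage points lower from compound 1 to compound 2 (within the scatter), the step to compound 4 is expected to be about a number 0.6 percentage points lower from compound 3 to compound 4 (within the scatter). Compound 4 is therefore estimated at 2%, expected to fall between 0% and 8%.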

Compound 4, a percentage reported as inhibition, in the whole organism at one dose (the size of the read-out at that dose, not a potency): 2.1%
For compound 4 the middle estimate is 0.1 percentage points below the measured one; the measured number falls inside the stated range.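

Chloro in place of hydrogen reads alike on both cores, with a new step in this assay of a number 0.5 percentage points lower from compound 3 to compound 4 (within the scatter): the same change on two cores in this assay, a number 0.6 percentage points lower (within the scatter) from compound 1 to compound 2 and a number 0.5 percentage points lower (within the scatter) from compound 3 to compound 4, 0.1 percentage points apart, within the scatter of two such steps.
The change to 3-nitrophenyl from 4-bromophenyl also reads alike, with a new step of a number 0.6 percentage points higher from compound 2 to compound 4 (within the scatter): the same change on two cores in this assay, a number 0.5 percentage points higher (within the scatter) from compound 1 to compound 3 and a number 0.6 percentage points higher (within the scatter) from compound 2 to compound 4, 0.1 percentage points apart, within the scatter of two such steps.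
Among the compounds shown here, all these steps lie within the scatter, so this shows only that neither change gave a detectable step on either core, not that either change has a real effect that carries from one core to another.

The compounds shown leave open whether a different group on the benzyl ring, such as an amine or a carboxylic acid, would give a step beyond the scatter.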